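A few compounds are considered here, and "the series" means these few. Any claim that something is new, unique, unknown or untested is made for them only; others in the source may bear on it.

Compound 1 `O=C(O)[C@H](CO)NC(=O)[C@H]1C[C@H](O)CN1`: > 12 h, a limit
Compound 2 `O=C(N[C@H](CO)C(=O)O)[C@@H]1C[C@H](O)CN1`: > 12 h, a limit

In an ADME assay on Jejunum (Mus musculus, strain C57BL/6) for metabolic stability, read by HPLC, with a stated time of 12 h (a higher number here means that the compound lasts longer, a lower number that the compound disappears faster), compound 2 stands at > 12 h, which is a limit and not a number. Compound 3 `O=C(O)[C@H](CO)NC(=O)[C@@H]1C[C@H](O)CN1` differs from compound 2 by the two compounds have the same atoms and bonds and differ only in configuration as drawn: 1 of 3 stereo elements differ; a stereocentre at a saturated chain carbon is drawn R in compound 2 and S in compound 3: a stereocentre at a saturated chain carbon is drawn R in compound 2 and S in compound 3. Among the compounds with values here, the only measured step bearing on this change is a step that the two limits leave unreadable from compound 1 to compound 2, so it offers no size to carry over. In this assay, no step beyond the scatter is expected, although the uncertainty is wide and a drop cannot be excluded. The expected change is a number no higher from compound 2 to compound 3 (the limit leaves the size open). For compound 3, the estimated half-life is 12 h, with an expected range of 3 h to 24 h.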

Compound 3, half-life: 0.39 h
The estimate for compound 3 lay 31-fold (1.49 log units) above the measured number; measured number outside the range, below it.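

In this assay, configuration alone proves enough to shorten the half-life sharply: changing one stereocentre at a saturated chain carbon gives an at least 30-fold lower number from compound 2 to compound 3 (1.48 log units; beyond the scatter). Changing one stereocentre at a saturated ring carbon gives an at least 30-fold lower number from compound 1 to compound 3 (1.48 log units; beyond the scatter), so either single change has a large effect in this series. The step from compound 1 to compound 2, where both centres differ, cannot be read, since both its ends are limits.

From the compounds shown here alone, how much larger these two steps really are stays open. Also open, going by these compounds, is how a methyl ester in place of the carboxylic acid would behave on any of these configurations.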